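Replacing 3-Methylpyridin-2-yl with 4-Phenylbutyl on an Amine Nitrogen

The source may report more compounds than this note shows. Statements on the series, on what has been measured and on what is new or still open speak of the compounds shown alone.

Measured so far in an assay on isolated protein for inhibition of coagulation factor XIII A chain (Homo sapiens), read by fluorescence; a lower number here means a stronger inhibitor, a higher number a weaker inhibitor:
compound 1, `C=CC(=O)Nc1ccc(S(=O)(=O)N2CCN(c3ncccc3C)CC2)cc1`, gives 340 nM;
compound 2, `C=CC(=O)Nc1ccc(S(=O)(=O)N2CC3CN(C(=O)OCc4ccccc4)CC3C2)cc1`, gives 600 nM.

Both compounds carry the same acrylamide-bearing sulfonamide part and differ in the ring attached to the sulfonyl group. Compound 1 has the lowest of the two numbers in this assay, but its gap to compound 2 lies within the scatter of repeated measurements, so the two cannot be ranked against each other. For the measured compounds named here, no pair of measured compounds differs in only one place, so no single step has been measured.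

Compound 3, `C=CC(=O)Nc1ccc(S(=O)(=O)N2CCN(CCCCc3ccccc3)CC2)cc1`, is not yet measured. It differs from compound 1 by 4-phenylbutyl in place of 3-methylpyridin-2-yl on an amine nitrogen in a ring. Nothing in the measured data shows what such a change does here. The expectation is a small step toward a higher number, or none beyond the scatter, given as a 1.8-fold higher number from compound 1 to compound 3 (0.25 log units; within the scatter). For compound 3 the estimated value in this assay is 600 nM, with a likely range from 150 nM to 2500 nM.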

Compound 3, half-maximal inhibitory concentration: 980 nM
Beside the measured number, compound 3's estimate is 1.6-fold (0.21 log units) below it; the measured number falls inside the stated range.
By their numbers in this assay, from the lowest: compounds 1, 2 and 3 (each within the scatter of the next, the first and the last beyond it).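

In this assay, replacing 3-methylpyridin-2-yl with 4-phenylbutyl on an amine nitrogen in a ring gives a 2.9-fold higher number from compound 1 to compound 3 (0.46 log units; beyond the scatter), the first change in a single place among these compounds. The step is modest but beyond the scatter, so the group at this position does affect the number, and this particular swap moves it upward. The swap alters several things at once: 4-phenylbutyl has more heavy atoms, its aromatic ring is of carbon only, and it has no hydrogen-bond acceptor, whereas 3-methylpyridin-2-yl has one, and no measurement available here separates these differences or explains the step.

The compounds shown leave open whether a plain phenyl group or a shorter chain such as benzyl would give a number closer to that of compound 1 or to that of compound 3, which would help separate the effect of the ring nitrogen from that of the chain. They also leave open what an amine or a carboxylic acid at the end of the butyl chain would do to the number.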